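Expecting the Lipophilicity of an Acetoxyphenyl Analogue

This account rests on a few compounds, and the source may have more. Where it says the series, first, only, none or still open, it means among the compounds named here.

Measured so far:
compound 1, `C/C(CC(=O)Nc1nnc(-c2ccc(O)cc2)s1)=N\c1ccc([N+](=O)[O-])cn1`, gives 3.34 in a physicochemical assay for lipophilicity, measured as octanol-water partition; on this read-out lower numbers stand for lower lipophilicity and higher numbers for higher lipophilicity;
compound 2, `C/C(CC(=O)Nc1nnc(-c2ccc(N)cc2)s1)=N\c1ccc([N+](=O)[O-])cn1`, gives 3.21.

Among these two, compound 2 stands at the lower number, and the step of a number 0.13 log units lower from compound 1 to compound 2 (within the scatter) lies within the scatter. Compound 3, `CC(=O)Oc1ccccc1-c1nnc(NC(=O)C/C(C)=N/c2ccc([N+](=O)[O-])cn2)s1`, differs from compound 2 by 2-acetoxyphenyl in place of 4-aminophenyl on an aromatic carbon. Among the measured compounds shown here, no measured step covers this change; the one step known, a number 0.13 log units lower from compound 1 to compound 2 (within the scatter), tells only that exchanging hydroxy for amino barely moved this assay. A rise beyond the scatter is expected, a number 0.39 log units higher from compound 2 to compound 3 (beyond the scatter), so compound 3 is estimated at 3.6, between 3.1 and 4.1.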

Compound 3, partition coefficient: 3.56
For compound 3 the middle estimate is 0.04 log units above the measured one; the measured number falls inside the stated range.
By their numbers in this assay, from the lowest: compounds 2, 1 and 3 (each within the scatter of the next, the first and the last beyond it).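

Among the compounds shown here, at this position on the shared core, 2-acetoxyphenyl gives the first step beyond the scatter in this assay, a number 0.35 log units higher from compound 2 to compound 3 (beyond the scatter), when it enters in place of 4-aminophenyl. Set against 4-hydroxyphenyl, the same group does not clear the scatter, a number 0.22 log units higher from compound 1 to compound 3 (within the scatter), so the two earlier compounds cannot be told apart by it. Nothing available explains either step.

The compounds shown do not separate the effect of the acetoxy group from that of its place on the phenyl ring. Going by these compounds, how a 2-methoxyphenyl group or a carboxylic acid on that ring would read also remains open.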